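From 3,4,5-Trimethoxyphenyl to Phenyl on the Shared Core

The source may report more compounds than this note shows. Statements on the series, on what has been measured and on what is new or still open speak of the compounds shown alone.

Among the compounds with values here, in a functional assay on HCT-116 cells (Homo sapiens) for antiproliferative activity, read by MTT assay, with a stated time of 48 h (on this read-out higher numbers stand for weaker inhibition and lower numbers for stronger inhibition), compound 2 (`COc1ccc(CN(C(=O)CSc2nc3ccccc3s2)c2cc(OC)c(OC)c(OC)c2)cc1O`) gives 182 nM and stands clearly apart from the other two compounds measured so far. Compound 3 (`COc1cc(CN(C(=O)CSc2nc3ccccc3s2)c2cc(OC)c(OC)c(OC)c2)cc(OC)c1OC`) gives 65300 nM and so holds the highest of the actual numbers. That gap reads a 360-fold higher number from compound 2 to compound 3 (2.55 log units; beyond the scatter) and is large. Compound 1 (`COc1cc(N(Cc2ccc(C)cc2)C(=O)CSc2nc3ccccc3s2)cc(OC)c1OC`) returns only a limit of the assay, > 80000 nM and no exact number.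

Compound 4 (`COc1cc(N(Cc2ccccc2)C(=O)CSc2nc3ccccc3s2)cc(OC)c1OC`) has not yet been measured. It carries phenyl in place of 3,4,5-trimethoxyphenyl on a saturated chain carbon bound to an amide-type nitrogen, and the counted change is phenyl in place of 3,4,5-trimethoxyphenyl on a saturated chain carbon bound to an amide-type nitrogen with the rest of the structure untouched.

The nearest guide is the exchange of 4-methylphenyl for 3,4,5-trimethoxyphenyl, where an at least 1.2-fold lower number from compound 1 to compound 3 (0.08 log units; that floor lies within the scatter) leaves only a floor within the scatter. The large steps, such as an at least 430-fold lower number from compound 1 to compound 2 (2.64 log units; beyond the scatter) on the way to compound 2, involve 3-hydroxy-4-methoxyphenyl, a group that compound 4 lacks. In this assay no step beyond the scatter is therefore expected, and the estimated step is a 1.1-fold higher number from compound 3 to compound 4 (0.03 log units; within the scatter) in either direction. A limit instead of a number is also quite possible. Compound 4 is expected at about 70000 nM (estimated range 25000 nM to 150000 nM).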

Compound 4, half-maximal inhibitory concentration: 54500 nM
Compound 4: middle estimate off by 1.3-fold (0.11 log units), on the high side, and the stated range covers the measured number.
By their numbers in this assay, from the lowest: compound 2; then compounds 4 and 3 (each within the scatter of the next). At a limit, above all of these: compound 1.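

In this assay, phenyl in place of 3,4,5-trimethoxyphenyl on a saturated chain carbon bound to an amide-type nitrogen gives a 1.2-fold lower number from compound 3 to compound 4 (0.08 log units; within the scatter), so this exchange now rests on two actual numbers rather than on a floor, and the unsubstituted ring cannot be told apart from the trimethoxylated one. The large distance to compound 2 also holds against the plain ring, at a 300-fold higher number from compound 2 to compound 4 (2.48 log units; beyond the scatter), which leaves 3-hydroxy-4-methoxyphenyl alone among the four groups at this place in reaching a clearly lower number. The exchange of hydrogen in place of methyl on an aromatic carbon yields only an at least 1.4-fold lower number from compound 1 to compound 4 (0.16 log units; that floor lies within the scatter), and this floor fixes no real size for the step, since compound 1 stands at a limit and not at a number: the limit of > 80000 nM in this assay, at which 1 of the 4 values shown sits.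

The compounds shown leave open whether the hydroxyl alone carries the gap to compound 2 or needs the neighbouring methoxy group, a question that 3-hydroxyphenyl and 4-methoxyphenyl at this place would separate. They also leave open whether an amine, as in 3-amino-4-methoxyphenyl, could stand in for that hydroxyl.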